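Swapping hydroxy for nitro on the aryl of compound 1

A few compounds are considered here, and "the series" means these few. Any claim that something is new, unique, unknown or untested is made for them only; others in the source may bear on it.

Compound 1 `Oc1ccc(CNc2cc(C(F)(F)F)cc3[nH]ncc23)cc1`: 36700 nM
Compound 2 `FC(F)(F)c1cc(NCC2CNC2)c2cn[nH]c2c1`: > 100000 nM, a limit of the assay
Compound 3 `FC(F)(F)c1cc(NC[C@H]2CCCCN2)c2cn[nH]c2c1`: 24000 nM

In an assay for inhibition of Indoleamine 2,3-dioxygenase 1 (Homo sapiens), with stated times of 10 min and 60 min (a higher number here means a weaker inhibitor, a lower number a stronger inhibitor), compound 1 gives 36700 nM, the highest of the two numbers shown. Among the compounds with values here, its only neighbour among the numbers lies within the scatter, as a 1.5-fold lower number from compound 1 to compound 3 (0.18 log units; within the scatter) shows. Compound 2 reports only a limit of the assay, > 100000 nM. The measured steps all exchange the whole 4-hydroxyphenyl group for a saturated ring: an at least 2.7-fold higher number from compound 1 to compound 2 (0.43 log units; beyond the scatter) and an at least 4.1-fold lower number from compound 2 to compound 3 (0.61 log units; beyond the scatter) are both beyond the scatter, while a 1.5-fold lower number from compound 1 to compound 3 (0.18 log units; within the scatter) is not. Their limit nature rests on (the limit of > 100000 nM in this assay, at which 1 of the 3 values shown sits).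

Compound 4 `O=[N+]([O-])c1ccc(CNc2cc(C(F)(F)F)cc3[nH]ncc23)cc1` keeps the shared core and the aryl ring of compound 1 and differs only in one group: nitro in place of hydroxy on an aromatic carbon. Within the data shown here, none of the measured steps touches the hydroxy group alone; each replaces the ring that carries it. So nothing measured here points to a direction for this exchange, and the expectation for compound 4 is a step of no size beyond the scatter, a 1.0-fold lower number from compound 1 to compound 4 (0.02 log units; within the scatter). Compound 4 is therefore estimated to give 35000 nM in this assay, with a range from 8000 nM to 150000 nM.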

Compound 4, half-maximal inhibitory concentration: 61000 nM
Estimate against measurement, compound 4: 1.7-fold (0.24 log units) below; the measured number falls inside the stated range.
By their numbers in this assay, from the lowest: compounds 3, 1 and 4 (each within the scatter of the next, the first and the last beyond it). At a limit, above all of these: compound 2.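

Within the data shown here, compound 4 is the first compound here in which the aryl ring stays and only the group on the aromatic carbon, para to a large group, is exchanged: in this assay this gives a 1.7-fold higher number from compound 1 to compound 4 (0.22 log units; within the scatter) for the exchange of hydroxy for nitro. This single pair therefore cannot separate the two groups, even though hydroxy carries a hydrogen-bond donor and nitro has none, and nitro is the larger group by heavy atoms. At this position in this series, then, the hydrogen-bond donor of hydroxy is not shown to matter, whereas the earlier steps could not address it, as each of them replaced the whole ring; the data given here hold no measurement that speaks to what lies behind this result.

Going by these compounds, whether an amine, a carboxylic acid or a methoxy group on this same aromatic carbon would stand beyond the scatter from compound 1 remains open, as does the ring with only hydrogen at this place. One pair also cannot say whether nitro and hydroxy would match in the same way on a different core.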